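The source may report more compounds than this note shows. Statements on the series, on what has been measured and on what is new or still open speak of the compounds shown alone.

In an ADME assay on microsomes from liver (Rattus norvegicus) for metabolic stability, read by LC-MS, with a stated time of 30 min, tested at 1 uM (a higher number here means that more of the compound is left, a lower number that less of the compound is left), compound 3 `CCN(CC)Cc1cc(C)cc(Nc2nc3ccccc3n2Cc2ccc(C(F)(F)F)cc2)c1O` stands at < 7% as a limit of the assay and not as a number. Compound 2 `CCNCc1cc(C)cc(Nc2nc3ccccc3n2Cc2ccc(C(F)(F)F)cc2)c1O` gives 51% in the same read-out and compound 1 `CC(C)(C)NCc1cc(Cl)cc(Nc2nc3ccccc3n2Cc2ccc(C(F)(F)F)cc2)c1O` gives 9% on the same terms.

Next in line is compound 4 `Cc1cc(CNC(C)(C)C)c(O)c(Nc2nc3ccccc3n2Cc2ccc(C(F)(F)F)cc2)c1` with the change (tert-butyl)amino in place of diethylamino on a saturated chain carbon bound to an aromatic carbon so that (tert-butyl)amino stands in place of diethylamino on a saturated chain carbon bound to an aromatic carbon.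

Among the measured compounds shown here, one measured step bears directly on this amine: a number at least 44 percentage points lower from compound 2 to compound 3 (beyond the scatter) came with ethyl in place of hydrogen on an amine nitrogen and was large and beyond the scatter. Compound 4 regains a hydrogen on that nitrogen as compound 2 has it, which points upward. Against that, compound 1 carries (tert-butyl)amino and gives 9% in this assay with chlorine where compound 4 has methyl, so the hydrogen alone need not restore a value like that of compound 2.

A modest upward step is therefore expected in this assay, estimated as a number at least 8 percentage points higher from compound 3 to compound 4 (that floor lies within the scatter) and probably not clear of the scatter. Compound 4 is estimated at 15% within an expected range of 5% to 40% and may still read only as a limit.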

Compound 4, percent of the compound remaining: 41%
Beside the measured number, compound 4's estimate is 26 percentage points below it; measured number above the stated range.
By their numbers in this assay, from the lowest: compound 1; then compounds 4 and 2 (each within the scatter of the next). At a limit, below all of these: compound 3.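

With (tert-butyl)amino in place of diethylamino on a saturated chain carbon bound to an aromatic carbon, this assay gives a number at least 34 percentage points higher from compound 3 to compound 4 (beyond the scatter), so a second amine with a hydrogen on its nitrogen now stands clear of the diethylamino compound, alongside compound 2. The size of this step is only a floor because compound 3 reads as a limit and not as a number: the limit of < 7% in this assay, at which 1 of the 4 values shown sits. Tert-butyl in place of ethyl on an amine nitrogen gives a number 10 percentage points lower from compound 2 to compound 4 (within the scatter), whereas methyl in place of chloro on an aromatic carbon gives a number 32 percentage points higher from compound 1 to compound 4 (beyond the scatter), so the low reading of compound 1 cannot be laid on (tert-butyl)amino alone.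

The compounds shown hold only one amine without a hydrogen on its nitrogen, so it remains open whether a ring amine such as pyrrolidine or morpholine would follow diethylamino, or whether isopropylamino or cyclopropylamino would follow the ethylamino and (tert-butyl)amino compounds. The chloro and methyl comparison also rests on one pair, which leaves open how fluoro or methoxy at that aromatic carbon would read, and whether the same step appears with ethylamino.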